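Turning One Double Bond in the Weakest Compound

A few compounds are considered here, and "the series" means these few. Any claim that something is new, unique, unknown or untested is made for them only; others in the source may bear on it.

- Compound 1 (`COc1cc(/C=C\c2cnc3ccccc3c2)cc(OC)c1OC`): 398 nM
- Compound 2 (`COc1cc(/C=C\c2ccc3cccnc3c2)cc(OC)c1OC`): 158 nM
- Compound 3 (`COc1cc(/C=C\c2ccc3nccnc3c2)cc(OC)c1OC`): 7940 nM

These values come from a functional assay on HCT-116 cells (Homo sapiens) for cytotoxicity (on this read-out lower numbers stand for stronger inhibition and higher numbers for weaker inhibition), and span a wide range. Compound 3 has the highest number of the three, so it is the weakest of this small set, and its gaps to compound 1 and compound 2 both lie well beyond the scatter.

Compound 4 (`COc1cc(/C=C/c2ccc3nccnc3c2)cc(OC)c1OC`) stays very close to compound 3 on paper. The difference is this: the two compounds have the same atoms and bonds and differ only in configuration as drawn: 1 of 1 stereo elements differ; a double bond is drawn Z in compound 3 and E in compound 4. In other words, a double bond is drawn Z in compound 3 and E in compound 4.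

Within the data shown here, no measured compound has this double bond drawn E, so the data give no direct measure of the change. The expectation is therefore a cautious one: a modest shift toward weaker inhibition, with wide uncertainty. The estimated change is a 2.0-fold higher number from compound 3 to compound 4 (0.30 log units; within the scatter), toward a higher number. For compound 4 the expected value is 16000 nM, with an estimated range from 4000 nM to 60000 nM in this test.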

Compound 4, half-maximal inhibitory concentration: > 15800 nM
Compound 4: a limit, no number (the forecaster's own chance of this, stated with the estimate: 40%); the middle value does not contradict the limit.
By their numbers in this assay, from the lowest: compound 2; then compound 1; then compound 3. At a limit, above all of these: compound 4.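

In this assay compound 4 gives > 15800 nM, which is a limit of the test and not a number. On these data alone, the change reads as an at least 1.9-fold higher number from compound 3 to compound 4 (0.29 log units; that floor lies within the scatter), so its true size stays unknown, and the floor alone does not separate the two compounds beyond the usual scatter. Among these compounds, compound 4 is the first compound here with the double bond drawn E, and the comparison with the Z form isolates that one feature: the fact that compounds 3 and 4 differ only in the configuration as drawn.

As far as these compounds go, whether turning the double bond has a similar outcome on the cores of compound 1 and compound 2 remains open. Also open, from the compounds shown here alone, is whether an amine or a hydroxyl group on the core of compound 4 would bring a measurable number in this test.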